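This account rests on a few compounds, and the source may have more. Where it says the series, first, only, none or still open, it means among the compounds named here.

Measured so far in a toxicity assay on NIH3T3 cells (Mus musculus) for cytotoxicity, read by resazurin assay; on this read-out higher numbers stand for an effect only at larger amounts of compound and lower numbers for an effect already at smaller amounts:
- compound 1, `c1ccc(Cn2cncc2CNc2cccc(-c3ccccc3)c2)cc1`, gives > 750 nM.
- compound 2, `Clc1ccc(Cn2cncc2CNc2cccc(-c3ccccc3)c2)cc1`, gives 10000 nM.

For compound 1 this assay reports only a limit, > 750 nM, and not a number (the limit of > 750 nM in this assay, at which 1 of the 2 values shown sits). Compound 2 carries a chloro in place of hydrogen on an aromatic carbon, and in this assay compound 2 gives 10000 nM. Among the compounds with values here, the only step among the measured compounds, a step that the limit leaves unreadable from compound 1 to compound 2, is one whose size cannot be read, since the value at its start is a limit. Where compound 1 stands is therefore known only as this limit, not as a point on the scale.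

Compound 3, `CC(C)c1cccc(NCc2cncn2Cc2ccccc2)c1`, has not yet been measured. It differs from compound 1 by isopropyl in place of phenyl on an aromatic carbon. Within the data shown here, no measured step touches this change: the one step known concerns a chloro on a different ring and its size is unreadable, so nothing here points to a direction. Both measured compounds show an effect only at large amounts, and a similar picture is expected for compound 3, with a step that the limit leaves unreadable from compound 1 to compound 3 that is estimated to stay within the scatter. The value expected for compound 3 in this assay is 8000 nM, estimated to fall between 2000 nM and 30000 nM.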

Compound 3, half-maximal effective concentration: > 1000 nM
Compound 3 ended at the assay's limit; the forecaster's own chance of this, stated with the estimate: 45%; the middle value is on the limit's open side.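

In this assay compound 3 gives > 1000 nM, which is a limit and not a number. Within the data shown here, compound 1 also has only a limit, and no step between compound 1 and compound 3 can be read. The compounds shown leave open whether isopropyl in place of phenyl on an aromatic carbon changes the amount needed for an effect on these cells.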